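The compounds below may be only part of what the source reports. "The series", "measured", "known", "first", "only" and "open" are said of these compounds alone.

Measured in an ADME assay on microsomes from liver (Canis lupus familiaris) for metabolic stability, with a stated time of 10 min, tested at 1 uM (on this read-out lower numbers stand for a less stable compound and higher numbers for a more stable compound), so far:
- compound 1 `COc1c(-c2ccc(C(F)(F)F)cc2Cl)ccc2c1cnn2[C@@H](CC(C)C)c1ccc(C(=O)NCCC(=O)O)cc1` gives 64%
- compound 2 `COc1c(-c2ccc(C(F)(F)F)cc2Cl)ccc2nn([C@@H](CC(C)C)c3ccc(C(=O)NCCC(=O)O)cc3)cc12` gives 76%
- compound 3 `Cc1cc(C(F)(F)F)ccc1-c1cc2cnn([C@@H](CC(C)C)c3ccc(C(=O)NCCC(=O)O)cc3)c2cc1C` gives 80%

Compound 1 stands lowest of the three, and the gaps to compound 2 and to compound 3 both lie beyond the scatter. The next structure is compound 4 `Cc1c(-c2ccc(C(F)(F)F)cc2Cl)ccc2c1cnn2[C@@H](CC(C)C)c1ccc(C(=O)NCCC(=O)O)cc1`, which has methyl in place of methoxy on an aromatic carbon, ortho to a 2-chloro-4-(trifluoromethyl)phenyl group, and is otherwise the same as compound 1. The counted change is methyl in place of methoxy on an aromatic carbon in this comparison.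

Among the compounds with values here, no measured pair isolates this swap, so the expectation rests on indirect evidence. Compound 3, which has no methoxy group, gives 80% but also differs from compound 1 elsewhere. Compound 2 keeps the methoxy group and still gives 76% on a differently arranged core, so the presence of methoxy does not by itself go with the lowest number. A small rise in this assay is therefore expected, with a fall not excluded. The expected step is a number 8 percentage points higher from compound 1 to compound 4 (within the scatter) in this read-out. For compound 4 the estimated value is 72% with an expected range from 58% to 86% for a single measurement.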

Compound 4, percent of the compound remaining: 31%
The estimate for compound 4 lay 41 percentage points above the measured number, outside the stated range (below it).
By their numbers in this assay, from the lowest: compound 4; then compound 1; then compounds 2 and 3 (each within the scatter of the next).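

In this assay, within the data shown here, the swap of methoxy for methyl on the aromatic carbon ortho to a 2-chloro-4-(trifluoromethyl)phenyl group gives a number 33 percentage points lower from compound 1 to compound 4 (beyond the scatter), the first step that can be read at a single place. Among these compounds, this position is therefore not indifferent: on this core, one change at this carbon moves the number beyond the scatter, and the methoxy compound is the one with the higher number, which no earlier pair could show. Nothing measured here bears on what lies behind this step.

The compounds shown leave open whether the step follows the oxygen of the methoxy group or some other feature of the two groups, which an ethoxy group, a hydroxy group, a chlorine atom or plain hydrogen on the same carbon would help to separate. They also leave open whether the same swap gives a step of similar size on the differently arranged core of compound 2, where the methoxy group also stands and a methyl counterpart would be the one-place comparison.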